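Replacing the pyrazole side group of compound 2 with 2-fluorophenyl

A few compounds are considered here, and "the series" means these few. Any claim that something is new, unique, unknown or untested is made for them only; others in the source may bear on it.

In a functional assay on NCI-H1993 cells (Homo sapiens) for inhibition, read by CCK-8 assay, with a stated time of 72 h (on this read-out higher numbers stand for weaker inhibition and lower numbers for stronger inhibition), compound 1 (`CNC(=O)c1ccc(-c2cnc3ncn(C(C)c4cc5cccnc5cc4F)c3n2)cc1F`) gives 32.7 nM and compound 2 (`OCCn1cc(-c2cnc3ncn(Cc4ccc5ncccc5c4)c3n2)cn1`) gives 2330 nM as the higher number of the two, a gap beyond the scatter. Among the compounds with values here, these two compounds differ in more than one place, so no measured step speaks directly to the next change. Compound 3 (`Fc1ccccc1-c1cnc2ncn(Cc3ccc4ncccc4c3)c2n1`) carries 2-fluorophenyl in place of 1-(2-hydroxyethyl)-1H-pyrazol-4-yl on an aromatic carbon of the shared core, and 2-fluorophenyl in place of 1-(2-hydroxyethyl)-1H-pyrazol-4-yl on an aromatic carbon counts what that exchange removes and adds. No step beyond the scatter is expected in this assay and any direction is only tentatively toward a lower number. The expected move is a 1.6-fold lower number from compound 2 to compound 3 (0.19 log units; within the scatter) with wide uncertainty. For compound 3 the estimate is 1500 nM and the expected range runs from 300 nM to 7000 nM as a working figure.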

Compound 3, half-maximal inhibitory concentration: > 10000 nM
Compound 3 was reported as a limit; the forecaster's own chance of this, stated with the estimate: 10%; middle value at least 6.6-fold (0.82 log units) away from the limit.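

In this assay, with the rest of compound 2 unchanged, 2-fluorophenyl in place of 1-(2-hydroxyethyl)-1H-pyrazol-4-yl on this aromatic carbon of the shared core gives an at least 4.2-fold higher number from compound 2 to compound 3 (0.63 log units; beyond the scatter). Within the data shown here, this is the first single-place step, and it shows that the group at this carbon matters to the read-out, with 1-(2-hydroxyethyl)-1H-pyrazol-4-yl giving the stronger inhibition of the two. Compound 3 is reported only as a limit, so the full size of the step stays unknown: the limit of > 10000 nM in this assay, at which 1 of the 3 values shown sits.

This single pair cannot separate the effect of losing the pyrazole ring from that of losing its hydroxyethyl chain. Also open, on these data alone, is whether a pyrazole bearing a longer chain ending in an amine, or a phenyl ring bearing a carboxylic acid, would give a number nearer that of compound 2.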